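From 2-methylpyridin-3-yl to 4-methylpyrimidin-5-yl

A few compounds are considered here, and "the series" means these few. Any claim that something is new, unique, unknown or untested is made for them only; others in the source may bear on it.

In an ADME assay on microsomes from liver (Rattus norvegicus) for metabolic stability (on this read-out lower numbers stand for a shorter-lived compound and higher numbers for a longer-lived compound), compound 1 `CC#C[C@@H](Cc1nnn[nH]1)c1ccc(OCc2ccc3scc(-c4cccnc4C)c3c2)cc1` gives 0.183 h and compound 2 `CC#C[C@@H](Cc1nnn[nH]1)c1ccc(OCc2ccc3sc(F)c(-c4ccc(OCCOC)cc4C)c3c2)cc1` gives 0.35 h. These two values lie within the scatter of each other, so neither compound stands apart on this read-out. Going by the values given here, compound 2 differs from compound 1 in more than one place, and the series offers no measured single-change step to calibrate against.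

Compound 3 `CC#C[C@@H](Cc1nnn[nH]1)c1ccc(OCc2ccc3scc(-c4cncnc4C)c3c2)cc1` carries 4-methylpyrimidin-5-yl in place of 2-methylpyridin-3-yl on an aromatic carbon of the five-membered aromatic ring with 1 sulfur, two ring bonds from the ring sulfur (4-methylpyrimidin-5-yl in place of 2-methylpyridin-3-yl on an aromatic carbon). Among the compounds with values here, with no measured precedent for this exchange, no shift beyond the scatter is expected in this assay, and no firm direction can be assigned. The expected change is small, estimated as a 1.2-fold higher number from compound 1 to compound 3 (0.08 log units; within the scatter). The estimate for compound 3 is 0.22 h, with an expected range of 0.1 h to 0.5 h.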

Compound 3, half-life: 0.333 h
Estimate against measurement, compound 3: 1.5-fold (0.18 log units) below, and the stated range covers the measured number.
By their numbers in this assay, from the lowest: compounds 1, 3 and 2 (each within the scatter of the next).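

On an aromatic carbon of the five-membered aromatic ring with 1 sulfur, two ring bonds from the ring sulfur, the series now has its first single-change step in this assay: 4-methylpyrimidin-5-yl in place of 2-methylpyridin-3-yl gives a 1.8-fold higher number from compound 1 to compound 3 (0.26 log units; within the scatter). A second nitrogen in the six-membered aromatic ring therefore does not separate the two compounds on this read-out. No measurement bearing on the cause of this result is available.

As far as these compounds go, whether an aromatic ring is needed at this position remains open, as does whether an amine or a carboxylic acid there would give a step beyond the scatter. Compound 2 differs from compound 1 in more than one place, so its number cannot be assigned to any single group.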